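The source may hold more compounds than are shown below. What is called first, only, known or untested is meant among the compounds shown, and "the series" means these compounds.

In a functional assay on the whole organism (strain albino) for inhibition, with Rattus norvegicus as the target, read by paw edema, with a stated time of 5 h, at a dose of 0.28 mmol/kg by the oral route (on this read-out lower numbers stand for less inhibition and higher numbers for more inhibition at the one dose given (going by the name of the read-out)), compound 1 `COc1ccc(-c2nnc(SCC(=O)c3ccccc3)n2-c2ccccc2)cc1OC` gives 59%. Among the compounds with values here, the only other number measured comes from compound 2 `O=C(CSc1nnc(-c2ccccc2)n1-c1ccccc1)c1ccccc1`, which in this assay gives 63%; the gap a number 4 percentage points higher from compound 1 to compound 2 (within the scatter) is the full picture of where compound 1 stands. Compound 3 `COc1cc(-c2nnc(SCC(=O)c3ccccc3)n2-c2ccccc2)cc(OC)c1OC` differs from compound 1 by methoxy in place of hydrogen on an aromatic carbon. Within the data shown here, the single step known, from compound 1 to compound 2, exchanged 3,4-dimethoxyphenyl for phenyl and stayed within the scatter, so one more methoxy is expected to move the number little. Compound 3 is estimated at 58%, between 45% and 70%, an expected step of a number 1 percentage points lower from compound 1 to compound 3 (within the scatter).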

Compound 3, a percentage reported as inhibition, in the whole organism at one dose (the size of the read-out at that dose, not a potency): 72%
Compound 3: the middle estimate sits 14 percentage points below what was measured, and the stated range ends below it.
By their numbers in this assay, from the lowest: compounds 1, 2 and 3 (each within the scatter of the next, the first and the last beyond it).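

In this assay, within the data shown here, a methoxy placed ortho to a methoxy group and meta to a large group gives the first change that goes beyond the scatter: a number 13 percentage points higher from compound 1 to compound 3 (beyond the scatter). This position on the aromatic ring therefore accepts the added group without loss, and the read-out responds to a change made there. No measurement here explains the rise. On these data alone, whether the gain is specific to methoxy remains open, as a hydroxyl group, an amine or the longer ethoxy at this position would show. Readings at one dose also leave potency open.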